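This account rests on a few compounds, and the source may have more. Where it says the series, first, only, none or still open, it means among the compounds named here.

Among the measured compounds shown here, compound 3 `CC1=NC(c2cn(S(=O)(=O)c3ccc(F)cc3)c3ccc(C)cc23)CN1` stands second highest of the three numbers so far in an assay on isolated protein for inhibition of kallikrein-7 (Homo sapiens), read by fluorescence, with stated times of 10 min and 30 min; on this read-out lower numbers stand for stronger inhibition and higher numbers for weaker inhibition: compound 3 gives 9400 nM, close to compound 2 `CC1=NC(c2cn(S(=O)(=O)c3cccs3)c3ccc(C)cc23)CN1` at 11000 nM, with a 1.2-fold lower number from compound 2 to compound 3 (0.07 log units; within the scatter), and far from compound 1 `CC1=NC(c2cn(S(=O)(=O)c3ccc(Cl)cc3)c3ccc(C)cc23)CN1` at 1900 nM, with a 4.9-fold higher number from compound 1 to compound 3 (0.69 log units; beyond the scatter). Compound 4 `CC1=NC(c2cn(S(=O)(=O)c3cccc(Cl)c3)c3ccc(C)cc23)CN1` differs from compound 3 by 3-chlorophenyl in place of 4-fluorophenyl on a sulfonyl sulfur. For the measured compounds named here, two measured steps bear on this. The step of a 4.9-fold higher number from compound 1 to compound 3 (0.69 log units; beyond the scatter) shows that exchanging chloro for fluoro on the phenyl ring moved the number by a modest, clear amount. The step of a 5.8-fold higher number from compound 1 to compound 2 (0.76 log units; beyond the scatter) shows that replacing 4-chlorophenyl with thiophen-2-yl also cost a modest amount. Compound 4 carries chloro again, though as 3-chlorophenyl rather than the 4-chlorophenyl of compound 1, so the return of that benefit is uncertain. Compound 4 is therefore expected to show a modest step of a 2.4-fold lower number from compound 3 to compound 4 (0.37 log units; beyond the scatter) toward a lower number in this assay. Compound 4 is estimated at 4000 nM, within a range from 1500 nM to 12000 nM.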

Compound 4, half-maximal inhibitory concentration: 30000 nM
Beside the measured number, compound 4's estimate is 7.5-fold (0.88 log units) below it; measured number above the stated range.
By their numbers in this assay, from the lowest: compound 1; then compounds 3 and 2 (each within the scatter of the next); then compound 4.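

In this assay, the change from 4-chlorophenyl to 3-chlorophenyl gives the largest step in the set (a 16-fold higher number from compound 1 to compound 4 (1.20 log units; beyond the scatter)), so among these compounds the number depends on where the chloro stands on the phenyl ring and not only on its presence. Chloro alone does not bring a lower number, since 3-chlorophenyl also compares poorly with 4-fluorophenyl (a 3.2-fold higher number from compound 3 to compound 4 (0.50 log units; beyond the scatter)) and with thiophen-2-yl (a 2.7-fold higher number from compound 2 to compound 4 (0.44 log units; beyond the scatter)), which leaves compound 4 with the highest number of the four. No measurement here explains why this change has that result.

The compounds shown leave open whether a bromo, methyl or methoxy group in place of the chloro of compound 1 would keep or lower its number, or how an amine or a carboxylic acid on that phenyl ring would fare. All four share the same core, so they also say nothing about how changes to the core would affect the number.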